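Swapping benzyl for 1-phenylcyclopropyl: an untested position

A few compounds are considered here, and "the series" means these few. Any claim that something is new, unique, unknown or untested is made for them only; others in the source may bear on it.

Compound 1 `Cn1cnc(-c2nc(N)c3cc(Cc4ccccc4)sc3n2)c1` gives 2330 nM in a functional assay on CHO-K1 cells for antagonist activity at adenosine receptor A1 (Homo sapiens), read by a beta-galactosidase reporter and cAMP accumulation, with stated times of 15 min and 6 h; a lower number here means a stronger inhibitor, a higher number a weaker inhibitor.
Compound 2 `Nc1nc(-c2ccccc2)nc2sc(Cc3ccccc3)cc12` gives 151 nM.
Compound 3 `N#Cc1cccc(-c2nc(N)c3cc(Cc4ccccc4)sc3n2)c1` gives 222 nM.

Compound 3 holds the second highest of the three numbers; compound 2 stands nearest to it, a 1.5-fold higher number from compound 2 to compound 3 (0.17 log units; within the scatter), while compound 1 lies furthest, a 10-fold lower number from compound 1 to compound 3 (1.02 log units; beyond the scatter). Compound 4 `N#Cc1cccc(-c2nc(N)c3cc(C4(c5ccccc5)CC4)sc3n2)c1` differs from compound 3 in one place: 1-phenylcyclopropyl in place of benzyl on an aromatic carbon. Among the compounds with values here, none of the measured steps touches this group: a 15-fold lower number from compound 1 to compound 2 (1.19 log units; beyond the scatter) and a 10-fold lower number from compound 1 to compound 3 (1.02 log units; beyond the scatter), as well as the small step of a 1.5-fold higher number from compound 2 to compound 3 (0.17 log units; within the scatter), all change the aryl group elsewhere on the shared core. The data therefore give no direct guide, and the step expected here, a 1.4-fold higher number from compound 3 to compound 4 (0.13 log units; within the scatter), is estimated to stay within the scatter. Compound 4 is estimated at 300 nM, with a range from 100 nM to 1000 nM.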

Compound 4, inhibition constant: > 610 nM
Compound 4 was reported as a limit; the forecaster's own chance of this, stated with the estimate: 5%; at least 2.0-fold (0.30 log units) between middle value and limit.
By their numbers in this assay, from the lowest: compounds 2 and 3 (each within the scatter of the next); then compound 1.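

Within the data shown here, the earlier steps all changed the aryl group elsewhere on the shared core, so this is the first look at the position on the aromatic carbon next to the ring sulfur, and it proves sensitive. Putting 1-phenylcyclopropyl in place of benzyl gives an at least 2.7-fold higher number from compound 3 to compound 4 (0.43 log units; beyond the scatter) in this assay. That size is only a minimum, because the value of compound 4 is a limit and not a number: the limit of > 610 nM in this assay, at which 1 of the 4 values shown sits.

Still open, as far as these compounds go, is how a simple ethyl chain or a benzyl carrying an amine would fare at this position. Also open, from the compounds shown here alone, is whether 1-phenylcyclopropyl would cost as much with phenyl in place of 3-cyanophenyl.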